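The compounds below may be only part of what the source reports. "The series", "measured", "known", "first", "only" and "open" are said of these compounds alone.

Measured compounds:
compound 1, `O=S(=O)(/C=C\c1ncccc1F)c1ccccc1F`, 482 nM
compound 2, `O=S(=O)(/C=C\c1ncccc1Cl)c1ccccc1F`, 1030 nM
compound 3, `O=S(=O)(/C=C/c1ncccc1F)c1ccccc1Cl`, 122 nM

In an assay on U2OS cells for activation of nuclear factor erythroid 2-related factor 2 (Homo sapiens), read by beta-arrestin recruitment, with a stated time of 6 h (on this read-out higher numbers stand for an effect only at larger amounts of compound and lower numbers for an effect already at smaller amounts), compound 1 gives 482 nM and compound 2 gives 1030 nM. Between them lies one change, (chloro in place of fluoro on an aromatic carbon), and this gave a 2.1-fold higher number from compound 1 to compound 2 (0.33 log units; beyond the scatter). Compound 3 gives 122 nM in this assay, the lowest of the three numbers; its difference from compound 1 is not broken down here. Compound 4, `O=S(=O)(/C=C/c1ncccc1Cl)c1ccccc1Cl`, is not yet measured. It differs from compound 3 by the same change, (chloro in place of fluoro on an aromatic carbon), made on the core of compound 3 instead of the core of compound 1. Since this change on compound 1 gave a 2.1-fold higher number from compound 1 to compound 2 (0.33 log units; beyond the scatter), compound 4 is expected to show a step of about a 2.1-fold higher number from compound 3 to compound 4 (0.33 log units; beyond the scatter), which rests on that single earlier step alone. Compound 4 is therefore estimated at 260 nM, with a range from 120 nM to 560 nM.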

Compound 4, half-maximal effective concentration: 26 nM
Estimate against measurement, compound 4: 10-fold (1.00 log units) above; the measured number lies below the stated range.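

Made on the core of compound 3, chloro in place of fluoro on an aromatic carbon gave a 4.7-fold lower number from compound 3 to compound 4 (0.67 log units; beyond the scatter) in this assay. Set beside the earlier step, the same change did not carry over from one core to the other: the same change on two cores in this assay, a 2.1-fold higher number (0.33 log units; beyond the scatter) from compound 1 to compound 2 and a 4.7-fold lower number (0.67 log units; beyond the scatter) from compound 3 to compound 4, 10-fold (1.00 log units) apart, beyond the scatter of two such steps This shows that, across these two pairs, the size and direction of the step depend on the core carrying it, but it does not show which difference between the cores is responsible, and one step on each core gives no rule for a further core.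

The compounds shown leave open how a methyl, a methoxy or an amine at this place would read in this assay. They also leave open whether such groups would follow the same dependence on the core.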